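Compound 2 to compound 4: hydrogen in place of decyl

A few compounds are considered here, and "the series" means these few. Any claim that something is new, unique, unknown or untested is made for them only; others in the source may bear on it.

In a functional assay on PC-3 cells (Homo sapiens) for antiproliferative activity, read by WST assay, with a stated time of 72 h (on this read-out lower numbers stand for an effect already at smaller amounts and higher numbers for an effect only at larger amounts of compound), compound 1 `CCCCCCCC/C=C\c1c(C)cc(C)nc1CCCOC` reaches only a limit, > 30 uM. Compound 2 `CCCCCCCCCCc1c(C)c(CCCCCCCCCC)c2[n+](c1C)CCC2` gives 0.6 uM, and compound 3 `CCCCCCCC/C=C\c1c(C)c(/C=C\CCCCCCCC)c2[n+](c1C)CCC2` gives 1.1 uM. Among the measured compounds shown here, these are the only two true numbers, and they lie within the scatter of each other. Compound 4 `CCCCCCCCCCc1c(C)cc(C)[n+]2c1CCC2` differs from compound 2 in one place: hydrogen in place of decyl on an aromatic carbon. For the measured compounds named here, no measured pair isolates this change. Starting from compound 2 at 0.6 uM, a move to higher numbers beyond the scatter is expected in this assay. The expected size is an 8.3-fold higher number from compound 2 to compound 4 (0.92 log units; beyond the scatter). For compound 4 the estimated value is 5 uM, with an expected range from 1.5 uM to 20 uM.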

Compound 4, concentration for half-maximal effect: 0.9 uM
For compound 4 the middle estimate is 5.6-fold (0.74 log units) above the measured one; measured number outside the range, below it.
By their numbers in this assay, from the lowest: compounds 2, 4 and 3 (each within the scatter of the next). At a limit, above all of these: compound 1.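

In this assay, hydrogen in place of decyl on this aromatic carbon, two atoms from the ring nitrogen, gives a small step (a 1.5-fold higher number from compound 2 to compound 4 (0.18 log units; within the scatter)). Among the compounds shown here, the decyl group at this place can therefore be lost with the number staying within the scatter, and one decyl group on the shared core is enough for such a value, which the earlier compounds could not show. Nothing measured here gives a cause for this.

Going by these compounds, whether an amine, a carboxylic acid or a longer chain at this place would hold the number remains open. So does the outcome of replacing the remaining decyl group with hydrogen.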